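A few compounds are considered here, and "the series" means these few. Any claim that something is new, unique, unknown or untested is made for them only; others in the source may bear on it.

For the measured compounds named here, in a functional assay on SW-620 cells (Homo sapiens) for cytotoxicity (a lower number here means a stronger inhibitor of growth, a higher number a weaker inhibitor of growth), compound 1 (`COc1ccc(C2=C(c3ccc(SC)cc3)CC3CCCN3C2=O)cc1Br`) gives 5000 nM and compound 2 (`COc1ccc(C2=C(c3ccc(SC)cc3)CC3CCCN3C2=O)cc1`) gives 3000 nM, so compound 2 stands level with the only other measured compound. Compound 3 (`CSc1ccc(C2=C(c3ccc(O)cc3)C(=O)N3CCCC3C2)cc1`) has hydrogen in place of methyl on an oxygen on an aromatic ring, which turns 4-methoxyphenyl into 4-hydroxyphenyl: hydrogen in place of methyl on an oxygen on an aromatic ring. Going by the values given here, the one measured step, hydrogen in place of bromo, is a different change and offers only indirect guidance: a 1.7-fold lower number from compound 1 to compound 2 (0.22 log units; within the scatter). No shift beyond the scatter is therefore expected, and the expected step is no change at the digits printed from compound 2 to compound 3 (within the scatter). For compound 3 the estimated value is 3000 nM, within an expected range of 1000 nM to 9000 nM.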

Compound 3, concentration for 50% growth inhibition: > 100000 nM
Compound 3: no number, only a limit (the forecaster's own chance of this, stated with the estimate: 10%); middle value at least 33-fold (1.52 log units) away from the limit.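

Hydrogen in place of methyl on the oxygen on the aromatic ring gives an at least 33-fold higher number from compound 2 to compound 3 (1.52 log units; beyond the scatter), and the step that also removes the bromo gives an at least 20-fold higher number from compound 1 to compound 3 (1.30 log units; beyond the scatter). The methoxy group at this place therefore matters far more for growth inhibition in this assay than the bromo group, whose removal stayed within the scatter. Compound 3 gives only a limit, not a number: the limit of > 100000 nM in this assay, at which 1 of the 3 values shown sits.

The compounds shown do not tell why the hydroxy compound falls so far. They also leave open whether an ethoxy group, with its longer chain on this oxygen, or an amine in place of the methoxy would keep the growth inhibition.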